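This account rests on a few compounds, and the source may have more. Where it says the series, first, only, none or still open, it means among the compounds named here.

Measured so far in an ADME assay on Caco-2 cells (Homo sapiens) for permeability, read by LC-MS, in the apical to basolateral direction, with a stated time of 60 min, at pH 6.5; on this read-out lower numbers stand for lower permeability and higher numbers for higher permeability:
- compound 1 `O=C(NCc1cc(Cl)ccc1-n1cnnn1)[C@@H]1CC=NN1C(=O)[C@H](O)c1ccccc1F`: 8.9 10^-6 cm/s
- compound 2 `O=C(NCc1cc(Cl)ccc1-n1cnnn1)[C@@H]1CC=NN1C(=O)[C@H](O)c1ccccc1`: 7 10^-6 cm/s

Among the measured compounds shown here, compound 2 gives 7 10^-6 cm/s, which lies within the scatter of compound 1, the only other compound with a number so far. The next compound, compound 3 `CC(C)(C)C[C@@H](O)C(=O)N1N=CC[C@H]1C(=O)NCc1cc(Cl)ccc1-n1cnnn1`, has not yet been measured. It differs from compound 2 by a single change: neopentyl in place of phenyl on a saturated chain carbon bound to a carbonyl carbon and an oxygen on a saturated carbon. In words, this is neopentyl in place of phenyl on a saturated chain carbon bound to a carbonyl carbon and an oxygen on a saturated carbon.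

For the measured compounds named here, only one measured step bears on this, and only loosely: a 1.3-fold lower number from compound 1 to compound 2 (0.10 log units; within the scatter), with hydrogen in place of fluoro on an aromatic carbon. Going by the values given here, that step alters the group that leaves here but does not remove it, and no measurement yet shows what replacing phenyl with a chain does. On this thin evidence, no shift beyond the scatter is expected in this assay, though with real uncertainty. The expected change is a 1.1-fold higher number from compound 2 to compound 3 (0.06 log units; within the scatter). For compound 3 the estimated value is 8 10^-6 cm/s, with an expected range from 3 10^-6 cm/s to 18 10^-6 cm/s.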

Compound 3, apparent permeability: 24 10^-6 cm/s
For compound 3 the middle estimate is 3.0-fold (0.48 log units) below the measured one; the measured number lies above the stated range.
By their numbers in this assay, from the lowest: compounds 2 and 1 (each within the scatter of the next); then compound 3.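

In this assay, the saturated chain carbon bound to a carbonyl carbon and an oxygen on a saturated carbon proves to be a place where the group can move the number: neopentyl in place of phenyl gives a 3.4-fold higher number from compound 2 to compound 3 (0.54 log units; beyond the scatter), and neopentyl in place of 2-fluorophenyl gives a 2.7-fold higher number from compound 1 to compound 3 (0.43 log units; beyond the scatter), whereas swapping fluoro for hydrogen on the aromatic carbon gave only a 1.3-fold lower number from compound 1 to compound 2 (0.10 log units; within the scatter). The aromatic ring can therefore be replaced here by a chain with no ring without any loss on this read-out, and the swap leaves the count of hydrogen-bond donors and acceptors and the net charge unchanged. No measurement at hand accounts for the rise.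

The compounds shown leave open whether the higher number goes with the loss of the aromatic ring or with neopentyl itself, a question that a cyclohexyl group or an unbranched pentyl chain at this place would help to settle. They also leave open how the number would respond to an amine or a carboxylic acid on this chain.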